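A few compounds are considered here, and "the series" means these few. Any claim that something is new, unique, unknown or untested is made for them only; others in the source may bear on it.

Measured in a functional assay on HeLa cells (Homo sapiens) for antiproliferative activity, read by sulforhodamine B assay, with a stated time of 48 h; on this read-out lower numbers stand for stronger inhibition of growth and higher numbers for weaker inhibition of growth:
- compound 1 `Cc1ccc(-c2cn(CCCN3C(=O)COc4ccccc43)nn2)cc1`: 14300 nM
- compound 2 `COc1ccc2cc(-c3cn(CCCN4C(=O)COc5ccccc54)nn3)ccc2c1`: > 100000 nM

For the measured compounds named here, compound 1 holds the only actual number here, 14300 nM. The entry for compound 2, > 100000 nM, is a limit of the assay and not a number.

The next step leads to compound 3 `COc1ccc(-c2cn(CCCN3C(=O)COc4ccccc43)nn2)cc1`, which has methoxy in place of methyl on an aromatic carbon, para to a large group: methoxy in place of methyl on an aromatic carbon. Going by the values given here, no measured pair shows this change directly, so the expectation is loose. Compound 2 also carries a methoxy group, and its result of > 100000 nM tilts the expectation slightly towards weaker growth inhibition. In this assay, the expected step is small and probably within the usual scatter: a 1.4-fold higher number from compound 1 to compound 3 (0.15 log units; within the scatter). For compound 3 the estimated value is 20000 nM, with an expected range from 6000 nM to 70000 nM.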

Compound 3, concentration for 50% growth inhibition: 4900 nM
Compound 3: middle estimate off by 4.1-fold (0.61 log units), on the high side; measured number below the stated range.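

Swapping 4-methylphenyl for 4-methoxyphenyl gives a 2.9-fold lower number from compound 1 to compound 3 (0.47 log units; beyond the scatter) in this assay and so stronger inhibition of growth, the first direct reading of this change. It shows that this position, para to a large group, responds to the exchange of one small group, and that a methoxy group here goes with a measurable number. Compound 2 also carries a methoxy group, but its entry of > 100000 nM is a limit of the assay and not a number, so it gives no size to compare with this step.

Going by these compounds, whether an amine, a hydroxyl group or an ethoxy group at this same position would move the number further remains open. The results shown do not explain why methoxy gives the lower number here.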